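Octyl chain on the alkyne: extending the sulfonamide series

The source may hold more compounds than are shown below. What is called first, only, known or untested is meant among the compounds shown, and "the series" means these compounds.

compound 1 `CC(=O)Nc1nc(-c2cccc(NS(=O)(=O)c3ccc(Br)cc3)c2)cs1` — a functional assay on A-375 cells (Homo sapiens) for antiproliferative activity, read by trypan blue exclusion, with a stated time of 48 h, tested at 1 uM; on this read-out lower numbers stand for a stronger effect and higher numbers for a weaker effect at the one concentration tested: "not active" (no number reported)
compound 2 `CCCCC#Cc1ccc(S(=O)(=O)Nc2cccc(-c3csc(NC(C)=O)n3)c2)cc1` — this assay: 73.2%
compound 3 `C#Cc1ccc(S(=O)(=O)Nc2cccc(-c3csc(NC(C)=O)n3)c2)cc1` — this assay: 59.2%

Compound 3 holds the lowest of the two numbers, with compound 2 the nearest, and compound 1 stands apart without a number. The move to compound 4 `CCCCCCCCC#Cc1ccc(S(=O)(=O)Nc2cccc(-c3csc(NC(C)=O)n3)c2)cc1` is octyl in place of hydrogen on a triple-bonded carbon. Among the measured compounds shown here, the one measured step that bears on it is a number 14 percentage points lower from compound 2 to compound 3 (beyond the scatter); read the other way, a chain entering at that triple-bonded carbon raised the number. Octyl is longer than butyl, so an upward step in this assay of at least that size is expected, with a broad range given the single comparison. Compound 4 is expected to give 80% (range 62% to 96%). The expected step is a number 20.8 percentage points higher from compound 3 to compound 4 (beyond the scatter).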

Compound 4, a percentage reported as activity, at one concentration (the size of the read-out at that concentration, not a potency): 39.6%
For compound 4 the middle estimate is 40.4 percentage points above the measured one; measured number outside the range, below it.
By their numbers in this assay, from the lowest: compound 4; then compound 3; then compound 2.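

In this assay the chain on the triple-bonded carbon does not push the number one way: octyl in place of hydrogen gives a number 19.6 percentage points lower from compound 3 to compound 4 (beyond the scatter) while butyl stands on the higher side of hydrogen. Going from butyl to octyl gives a number 33.6 percentage points lower from compound 2 to compound 4 (beyond the scatter) so the direction depends on chain length, and compound 2 goes against any reading that a chain here lowers the number. Nothing at hand accounts for this reversal.

Chains between butyl and octyl could locate the turn. As far as these compounds go, whether a longer chain, or a chain ending in an amine or a carboxylic acid, extends the drop remains open.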